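The source may report more compounds than this note shows. Statements on the series, on what has been measured and on what is new or still open speak of the compounds shown alone.

Measured in a functional assay, with stated times of 30 s and 6 min, in the presence of a further agent that is not named here; on this read-out lower numbers stand for stronger inhibition and higher numbers for weaker inhibition:
- Compound 1 `CCOc1cc(OC)c(Br)cc1C(C)=O`: 37900000 nM
- Compound 2 `CCCCCCCCCCCCOc1cc(OC)c(Br)cc1C(C)=O`: 10600000 nM
- Compound 3 `CCOc1cc(OC)ccc1C(C)=O`: 6600000 nM

Compound 3 gives 6600000 nM, which lies within the usual scatter of compound 2 at 10600000 nM. These two sit at the low end of the three numbers, and compound 1 stands well above them.

The next compound is compound 4 `CCCCCCCCOc1cc(OC)ccc1C(C)=O`. Its change from compound 3 is hexyl in place of hydrogen on a saturated chain carbon, two bonds along the chain from an oxygen on an aromatic ring.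

Among the compounds with values here, only one measured step is on record, a 5.7-fold lower number from compound 1 to compound 3 (0.76 log units; beyond the scatter). It is a modest step, beyond the scatter, but it concerns hydrogen in place of bromo on an aromatic carbon, not the chain, so it bears on this change only indirectly. The sole hint on chain length comes from the two bromo compounds. Compound 1 gives 37900000 nM, and compound 2, with its dodecyl chain, gives the lower 10600000 nM. Within the data shown here, no such pair has been measured without bromo, so the hint may not carry over.

A small shift toward a lower number is therefore expected in this assay. The expected step is a 2.2-fold lower number from compound 3 to compound 4 (0.34 log units; beyond the scatter). For compound 4 the estimate is 3000000 nM, with an expected range from 800000 nM to 11000000 nM.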

Compound 4, half-maximal inhibitory concentration: 21200000 nM
For compound 4 the middle estimate is 7.1-fold (0.85 log units) below the measured one; measured number above the stated range.
By their numbers in this assay, from the lowest: compounds 3, 2, 4 and 1 (each within the scatter of the next, the first and the last beyond it).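

In this assay, hexyl in place of hydrogen on a saturated chain carbon, two bonds along the chain from an oxygen on an aromatic ring, gives a 3.2-fold higher number from compound 3 to compound 4 (0.51 log units; beyond the scatter). This is the first measured step at the chain itself, and it makes clear that lengthening the chain does not move the number the same way across the compounds shown: among the bromo compounds, compound 1 gives 37900000 nM and compound 2, with its dodecyl chain, gives the lower 10600000 nM, whereas the number rises here with hydrogen on that aromatic carbon, although the two pairs differ in chain length as well. No measurement at hand explains this difference in direction.

Within the data shown here, it remains open whether the bromo or the chain length decides the direction, since the dodecyl chain is seen only with bromo and the octyl chain of compound 4 only without it. Also open, as far as these compounds go, is how the number would respond to butyl or to a carboxylic acid in place of the hexyl on the core of compound 4.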